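This account rests on a few compounds, and the source may have more. Where it says the series, first, only, none or still open, it means among the compounds named here.

Measured so far in a functional assay on the whole organism (strain Kunming) with Mus musculus as the target, in the maximal electroshock model; a higher number here means that more compound is needed for the effect, a lower number that less compound is needed:
Compound 1 `O=C(/C=C/c1ccc(F)cc1)NCCO` gives 45.6 mg/kg
Compound 2 `O=C(/C=C/c1ccc(Cl)cc1)NCCO` gives 73.4 mg/kg
Compound 3 `O=C(/C=C/c1ccccc1F)NCCO` gives 35.3 mg/kg

Compound 3 lies within the scatter of compound 1 and clearly lower than compound 2. Compound 4 `O=C(/C=C/c1ccccc1Br)NCCO` is not yet measured. It differs from compound 3 by bromo in place of fluoro on an aromatic carbon with bromo in place of fluoro on an aromatic carbon, ortho to a group of 8 heavy atoms. Going by the values given here, no measured step brings in bromo. The closest is chloro in place of fluoro on an aromatic carbon, which gave a 1.6-fold higher number from compound 1 to compound 2 (0.21 log units; within the scatter) and offers only a rough guide. A similar small rise is expected here, an estimated 1.6-fold higher number from compound 3 to compound 4 (0.19 log units; within the scatter) and nothing clearly beyond the scatter. In this assay compound 4 is estimated at 55 mg/kg with a likely range from 28 mg/kg to 110 mg/kg for now.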

Compound 4, dose for half-maximal effect: 68.2 mg/kg
For compound 4 the middle estimate is 1.2-fold (0.09 log units) below the measured one; low and high end bracket the measured number.
By their numbers in this assay, from the lowest: compounds 3, 1, 4 and 2 (each within the scatter of the next, the first and the last beyond it).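

In this assay, bromo in place of fluoro on an aromatic carbon, ortho to a group of 8 heavy atoms, gives a 1.9-fold higher number from compound 3 to compound 4 (0.29 log units; within the scatter) and so stays inside the normal spread of repeat measurements. This place on the ring therefore holds either halogen without a change that can be told from that spread. No supporting measurement is available that bears on this result.

Still open, from the compounds shown here alone, is how this position responds to a group other than a halogen, such as methoxy or an amine, and how chloro behaves here.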